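Piperidine in Place of Methylpiperazine on a Quinoline Sulfone

The compounds below may be only part of what the source reports. "The series", "measured", "known", "first", "only" and "open" are said of these compounds alone.

Three compounds with the shared core share the same read-out in an assay on isolated protein for displacement of a labelled ligand from metabotropic glutamate receptor 5 (Homo sapiens), with a stated time of 60 min, tested at 1 uM; a higher number here means more inhibition at the concentration tested (going by the name of the read-out), a lower number less inhibition. Compound 1 `CC1CCN(c2c(S(=O)(=O)c3ccc(F)c(Cl)c3)cnc3cc(F)ccc23)CC1` gives 94% in this assay, and compound 2 `Cc1ccc2ncc(S(=O)(=O)c3ccccc3)c(N3CCC(C)CC3)c2c1` gives 67%. Compound 3 `CN1CCN(c2c(S(=O)(=O)c3ccccc3)cnc3ccccc23)CC1` gives 7.7% and stands lowest of the three numbers; both compound 2 and compound 1 lie above it by more than the usual scatter, compound 2 being the nearer of the two and compound 1 the further.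

Compound 4 `O=S(=O)(c1ccccc1)c1cnc2ccccc2c1N1CCCCC1` has not yet been measured in this assay. It differs from compound 3 in one place: piperidin-1-yl in place of 4-methylpiperazin-1-yl on an aromatic carbon. Going by the values given here, the amine that enters is of the same kind as the one carried by compound 2 and compound 1, apart from the 4-methyl; compound 2 gave 67% and compound 1 gave 94%, while compound 3, with the 4-methylpiperazin-1-yl, gave 7.7%. On that basis a step from compound 3 to compound 4 of a number 42.3 percentage points higher from compound 3 to compound 4 (beyond the scatter) is expected, upward and well beyond the scatter. Compound 4 is therefore estimated to give 50% in this assay, with a range from 20% to 80%.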

Compound 4, a percentage reported as inhibition, at one concentration (the size of the read-out at that concentration, not a potency): 71.4%
Beside the measured number, compound 4's estimate is 21.4 percentage points below it, and the stated range covers the measured number.
By their numbers in this assay, from the lowest: compound 3; then compounds 2 and 4 (each within the scatter of the next); then compound 1.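

In this assay, going by these compounds alone, putting piperidin-1-yl in place of 4-methylpiperazin-1-yl on the aromatic carbon opposite the ring nitrogen gives a number 63.7 percentage points higher from compound 3 to compound 4 (beyond the scatter), and this is the first change here that can be read on its own, since the earlier compounds all differ from one another in more than one place. The rest of the structure stays the same, so this position is shown to respond strongly to a small exchange: both groups are six-membered non-aromatic rings with no hydrogen-bond donors and no net charge, and they differ only in the second ring nitrogen and its methyl. Nothing given here bears on why the exchange has this effect.

The compounds shown leave open whether the second ring nitrogen or its methyl accounts for the step, a question that piperazin-1-yl or morpholin-4-yl at the same position would address. The contributions of the 4-methyl on the piperidine and of the other substituents in compound 1 and compound 2 cannot be read; each of those compounds differs from compound 4 in more than one place.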